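The compounds below may be only part of what the source reports. "The series", "measured", "known", "first", "only" and "open" are said of these compounds alone.

Measured compounds in the series:

compound 1 `OC(CCn1nc2c(Br)c(Br)c(Br)c(Br)c2n1)c1ccc(F)cc1` — 0%
compound 2 `COc1cccc(C(O)CCn2nc3c(Br)c(Br)c(Br)c(Br)c3n2)c1` — 48%
compound 3 `C[C@@H](O)CCn1nc2c(Br)c(Br)c(Br)c(Br)c2n1` — 36%

All three share the same core and differ only in the group on the saturated chain carbon bound to an oxygen on a saturated carbon and a saturated chain carbon. In a functional assay on CCRF-CEM cells (Homo sapiens) for antiproliferative activity, read by MTT assay, with a stated time of 24 h, tested at 100 uM (a lower number here means a stronger effect, a higher number a weaker effect of the compound at the concentration tested), compound 2 gives 48%, the highest of the three numbers; compound 3 gives 36%, a number beyond the scatter below it, and compound 1 gives 0%, the furthest below.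

The next compound, compound 4 `OC(CCn1nc2c(Br)c(Br)c(Br)c(Br)c2n1)c1ccc(Cl)cc1`, is not yet measured. Relative to compound 2 it carries 4-chlorophenyl in place of 3-methoxyphenyl on a saturated chain carbon bound to an oxygen on a saturated carbon and a saturated chain carbon.

Among the measured compounds shown here, only one measured step bears on this change: a number 48 percentage points higher from compound 1 to compound 2 (beyond the scatter). That step runs from a 4-fluorophenyl to a 3-methoxyphenyl, and compound 4 moves back toward a halogen-bearing phenyl, a 4-chlorophenyl. For the measured compounds named here, the single step does not tell whether a chlorine behaves like a fluorine here, so the expectation leans on it loosely. A large step downward, in the direction of compound 1, is expected, and the expected step is a number 36 percentage points lower from compound 2 to compound 4 (beyond the scatter). For compound 4 the estimated value in this assay is 12%, with a range from 0% to 38%.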

Compound 4, a percentage reported as activity, at one concentration (the size of the read-out at that concentration, not a potency): 0%
Compound 4: the middle estimate sits 12 percentage points above what was measured; the measured number falls inside the stated range.
By their numbers in this assay, from the lowest: compounds 1 and 4 (each within the scatter of the next); then compound 3; then compound 2.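

Exchanging the 3-methoxyphenyl for a 4-chlorophenyl on the saturated chain carbon in this assay gives a large step (a number 48 percentage points lower from compound 2 to compound 4 (beyond the scatter)), so the gap first seen with the 4-fluorophenyl group is not confined to that one group. Changing the halogen itself leaves the read-out unmoved (no change at the digits printed from compound 1 to compound 4 (within the scatter)), so chloro and fluoro on the aromatic carbon cannot be told apart here. Among the compounds shown here, with two halogen-bearing phenyl groups now on the same side of compound 2, the earlier single step becomes a small pattern across compound 1 and compound 4, with compound 2 as the only aromatic example outside it.

The 3-methoxyphenyl group differs from both 4-halophenyl groups in substituent and in its printed ring position together, so a 4-methoxyphenyl or a 3-chlorophenyl group would be needed to separate the two, and an unsubstituted phenyl group would give the reference for both. Nothing available explains the large gap between these aromatic groups at this position.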